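Fluoro for Hydroxy on the Chain of Compound 2

This account rests on a few compounds, and the source may have more. Where it says the series, first, only, none or still open, it means among the compounds named here.

compound 1 `CC(=O)OCCc1c(C)[nH]c(=O)[nH]c1=O`: > 100000 nM, a limit of the assay
compound 2 `COc1nc(C)c(CCO)c(OC)n1`: > 100000 nM, a limit of the assay
compound 3 `COc1nc(Cl)nc(C)c1CCO`: > 100000 nM, a limit of the assay

Three compounds were tested in a functional assay on SW-620 cells (Homo sapiens) for antiproliferative activity, read by MTT assay, with a stated time of 24 h; on this read-out higher numbers stand for weaker inhibition and lower numbers for stronger inhibition. None of them gave a number. For compound 2 the value is only a limit, so where it stands is known solely as a limit and not as a measured point. Going by the values given here, the one single-point change among the measured compounds, a step that the two limits leave unreadable from compound 2 to compound 3, cannot be sized, because both of its ends sit at the limit of > 100000 nM in this assay, at which 3 of the 3 values shown sit.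

Compound 4 `COc1nc(C)c(CCF)c(OC)n1` differs from compound 2 by fluoro in place of hydroxy on a saturated chain carbon, two bonds along the chain from an aromatic carbon. Among the compounds with values here, no measured step bears on this change: the only step that starts from compound 2 is unreadable, and no other pair of measured compounds shares it. With the starting point itself a limit, the outcome for compound 4 in this assay can only be expected to remain near that limit, with no direction beyond the scatter to be read from the data. Compound 4 is therefore expected to give about 100000 nM, in a range from 30000 nM to 300000 nM. That estimate amounts to an expected step of a number no higher from compound 2 to compound 4 (the limit leaves the size open), which is no step beyond the scatter.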

Compound 4, half-maximal inhibitory concentration: > 100000 nM
Compound 4: no number, only a limit; the forecaster's own chance of this, stated with the estimate: 85%; the middle value lies on the limit itself.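

In this assay no size can be read for the change from compound 2 to compound 4, since both ends are limits and not numbers: the limit of > 100000 nM in this assay, at which 4 of the 4 values shown sit.

The compounds shown leave open whether any change to the shared core would give a measurable value in this assay.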